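Replacing isopropyl with 4-bromobenzyl: what growth inhibition may follow

The compounds below may be only part of what the source reports. "The series", "measured", "known", "first", "only" and "open" are said of these compounds alone.

In a functional assay on K562 cells (Homo sapiens) for inhibition, read by luminescence, with a stated time of 72 h, tested at 5 uM (a higher number here means more inhibition of growth at the concentration tested, a lower number less inhibition of growth), compound 1 (`C=CS(=O)(=O)NC/C=C/c1cc(OC)cc(O)c1C(=O)OC(C)C`) gives 36.2%. Within the data shown here, its only measured neighbour, compound 2 (`C=CS(=O)(=O)NC/C=C/c1cc(OC)cc(O)c1C(=O)OCC1CCCCC1`), gives 27.4%. The two lie within the scatter of each other, so compound 1 holds no clear rank. Compound 3 (`C=CS(=O)(=O)NC/C=C/c1cc(OC)cc(O)c1C(=O)OCc1ccc(Br)cc1`) has not yet been measured. It differs from compound 1 by 4-bromobenzyl in place of isopropyl on an oxygen next to a carbonyl group. Among the measured compounds shown here, one measured step bears on this change, cyclohexylmethyl in place of isopropyl at the same place, and it amounts to a number 8.8 percentage points lower from compound 1 to compound 2 (within the scatter). On that single step, no change beyond the scatter is expected. For the measured compounds named here, no measured compound carries 4-bromobenzyl, so the range stays wide. The expected step is a number 5.2 percentage points lower from compound 1 to compound 3 (within the scatter). The estimated value for compound 3 is 31%, within an expected range from 15% to 48%.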

Compound 3, percent growth inhibition at one concentration: 38.4%
For compound 3 the middle estimate is 7.4 percentage points below the measured one, within the range that was stated.
By their numbers in this assay, from the lowest: compounds 2, 1 and 3 (each within the scatter of the next, the first and the last beyond it).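

Placed on an oxygen next to a carbonyl group, 4-bromobenzyl gives a number 2.2 percentage points higher from compound 1 to compound 3 (within the scatter), so a group carrying an aromatic ring can replace isopropyl here without a change beyond the scatter in this assay. The ring type at the far end of the group now separates two compounds: 4-bromophenyl in place of cyclohexyl on a saturated chain carbon bound to an oxygen next to a carbonyl group gives a number 11 percentage points higher from compound 2 to compound 3 (beyond the scatter), the only step shown that lies beyond the scatter, though a modest one. Compound 1, with no ring at this place, stays within the scatter of both compounds. Nothing available accounts for this step.

The compounds shown leave open whether the bromine or the aromatic ring itself goes with this step, a question that plain benzyl or 4-chlorobenzyl would bear on. They also leave open how a 2-aminoethyl group on the same oxygen would read.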